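Sulfonamide cyclopentane acids: fluoro to methyl swap

This account rests on a few compounds, and the source may have more. Where it says the series, first, only, none or still open, it means among the compounds named here.

Compound 1 `Cc1ccc(S(=O)(=O)N[C@H]2CC[C@H](O)[C@@H]2C/C=C\CCC(=O)O)cc1` and compound 2 `O=C(O)CC/C=C\C[C@@H]1[C@@H](NS(=O)(=O)c2ccc(F)cc2)CC[C@@H]1O` share one core. In a functional assay (plasma) for inhibition, with Homo sapiens as the target (on this read-out lower numbers stand for stronger inhibition and higher numbers for weaker inhibition), compound 1 gives 2500 nM and compound 2 gives 1600 nM. Among the compounds with values here, the single change between them is methyl in place of fluoro on an aromatic carbon. Compound 3 `O=C(O)CCC/C=C\C[C@@H]1[C@H](O)CC[C@H]1NS(=O)(=O)c1ccc(F)cc1` carries a core whose difference from that of compound 2 is not broken down here; in this assay compound 3 gives 6000 nM, the highest number of the three, with its steps to compound 1 and compound 2 both beyond the scatter. Compound 4 `Cc1ccc(S(=O)(=O)N[C@@H]2CC[C@@H](O)[C@H]2C/C=C\CCCC(=O)O)cc1` is not yet measured and differs from compound 3 by methyl in place of fluoro on an aromatic carbon, the same change at the same place as between compound 2 and compound 1. Compound 4 is expected to give 8000 nM, between 4000 nM and 16000 nM, because the same change earlier gave a 1.6-fold higher number from compound 2 to compound 1 (0.19 log units; within the scatter). The estimated step is a 1.3-fold higher number from compound 3 to compound 4 (0.12 log units; within the scatter), expected to stay within the scatter.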

Compound 4, half-maximal inhibitory concentration: 5800 nM
Estimate against measurement, compound 4: 1.4-fold (0.14 log units) above; the range from low to high includes it.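

On the core of compound 3, 4-methylphenyl in place of 4-fluorophenyl gives a 1.0-fold lower number from compound 3 to compound 4 (0.01 log units; within the scatter) in this assay. Set beside the earlier pair, the change shows no detectable difference between the two cores: the same change on two cores in this assay, a 1.6-fold higher number (0.19 log units; within the scatter) from compound 2 to compound 1 and a 1.0-fold lower number (0.01 log units; within the scatter) from compound 3 to compound 4, 1.6-fold (0.21 log units) apart, within the scatter of two such steps. Within the data shown here, this supports treating the swap as carrying over between these two cores with no step beyond the scatter, but with only two pairs and neither step beyond the scatter, it does not show a real effect of the change on either core or predict its outcome on any other core.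

On these data alone, whether chloro, trifluoromethyl or methoxy at the same place would give a step beyond the scatter remains open. Also open, as far as these compounds go, is whether the swap behaves alike with an amide in place of the carboxylic acid.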